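Hydroxy for chloro on the six-membered ring

The source may report more compounds than this note shows. Statements on the series, on what has been measured and on what is new or still open speak of the compounds shown alone.

Two closely related compounds have been measured in a functional assay on MOLT-4 cells (Homo sapiens) for antiproliferative activity; on this read-out higher numbers stand for weaker inhibition and lower numbers for stronger inhibition. Compound 1, `Nc1nc(Cl)c2ncn([C@H]3CCC[C@H]3CO)c2n1`, gives 49100 nM in this assay. Compound 2, `Nc1nc(Cl)c2nnn([C@H]3CCC[C@H]3CO)c2n1`, gives 75300 nM. Of these two numbers, compound 2 stands at the higher one, and compound 1 is its nearest neighbour; the two values lie within the scatter of one another, so nothing can be said about an order between them. Both numbers sit far up the concentration scale, and neither compound shows strong inhibition in this assay.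

Compound 3, `Nc1nc(O)c2nnn([C@H]3CCC[C@H]3CO)c2n1`, has not yet been measured. It differs from compound 2 in one place: hydroxy in place of chloro on an aromatic carbon. Going by the values given here, no step between two measured compounds exists to tell what this exchange does in this assay, so the expectation has to rest on compound 2 alone. Given that compound 2 already gives 75300 nM, a step upward is expected, toward even weaker inhibition, and the step from compound 2 to compound 3 is estimated at a 1.6-fold higher number from compound 2 to compound 3 (0.20 log units; within the scatter). Compound 3 is therefore expected to give about 120000 nM in this assay, with a range from 35000 nM to 400000 nM.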

Compound 3, half-maximal inhibitory concentration: 86000 nM
Estimate against measurement, compound 3: 1.4-fold (0.14 log units) above, and the stated range covers the measured number.
By their numbers in this assay, from the lowest: compounds 1, 2 and 3 (each within the scatter of the next).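

In this assay, going by these compounds alone, placing hydroxy instead of chloro on this aromatic carbon, next to the ring nitrogen, gives a 1.1-fold higher number from compound 2 to compound 3 (0.06 log units; within the scatter), the first step that can be read at this position. The entering hydroxy carries one hydrogen-bond donor and one hydrogen-bond acceptor and the leaving chloro carries neither, yet this exchange leaves the two compounds within the scatter of each other, and compound 3, at 86000 nM, stays far up the concentration scale, so the change opens no separation from compound 2 on this read-out. No independent evidence bears on why the step is this small.

The compounds shown leave open whether any group at this carbon would separate from chloro and hydroxy in this assay, for example an amine, a methoxy group or a thiol. They also leave open whether the same exchange of chloro for hydroxy would give a similarly small step on the core of compound 1, since that core appears here only with chloro.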